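Swapping the five-membered azole on a bicyclic adenosine receptor core

A few compounds are considered here, and "the series" means these few. Any claim that something is new, unique, unknown or untested is made for them only; others in the source may bear on it.

Compound 1 `Cc1ccc(Cn2c(=O)[nH]c3c(N)nc(-c4ncco4)cc32)cn1`: 970 nM in an assay on isolated protein for inhibition of adenosine receptor A1 (Homo sapiens); on this read-out higher numbers stand for weaker inhibition and lower numbers for stronger inhibition
Compound 2 `Cc1ccc(Cn2c(=O)[nH]c3c(N)nc(-n4nccn4)cc32)cn1`: 1900 nM in this assay

For the measured compounds named here, only two compounds have been measured. Going by the values given here, the step of a 2.0-fold higher number from compound 1 to compound 2 (0.29 log units; within the scatter) lies within the scatter, so compound 2 stands level with compound 1 on the numbers known so far. Compound 3 `Cc1ccc(Cn2c(=O)[nH]c3c(N)nc(-n4cccn4)cc32)cn1` is the next member, differing from compound 2 by 1H-pyrazol-1-yl in place of 2H-1,2,3-triazol-2-yl on an aromatic carbon. Among the compounds with values here, the one measured step that bears on this change is the earlier swap of one five-membered aromatic ring for another, a 2.0-fold higher number from compound 1 to compound 2 (0.29 log units; within the scatter), which stayed within the scatter. A step of similar size, not clearly in either direction, is therefore expected here. Compound 3 is estimated to give about 2000 nM in this assay, in the range 700 nM to 6000 nM, an expected step of a 1.1-fold higher number from compound 2 to compound 3 (0.02 log units; within the scatter).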

Compound 3, half-maximal inhibitory concentration in the adenosine receptor A1 assay: 2800 nM
The estimate for compound 3 lay 1.4-fold (0.15 log units) below the measured number, within the range that was stated.
By their numbers in the adenosine receptor A1 assay, from the lowest: compounds 1, 2 and 3 (each within the scatter of the next, the first and the last beyond it).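

For the compounds shown here, in the adenosine receptor A1 assay, 1H-pyrazol-1-yl in place of 2H-1,2,3-triazol-2-yl gives a 1.5-fold higher number from compound 2 to compound 3 (0.17 log units; within the scatter), while the same group in place of 1,3-oxazol-2-yl gives a 2.9-fold higher number from compound 1 to compound 3 (0.46 log units; beyond the scatter), the first step at this position to pass the scatter. In a physicochemical assay for solubility (a lower number here means a less soluble compound, a higher number a more soluble compound), compound 2 gives 123 ug/mL and compound 3 gives 45 ug/mL and the triazole and pyrazole compounds separate clearly, with the triazole compound the more soluble: the measured solubility of compound 2, 123 ug/mL, and of compound 3, 45 ug/mL, a 2.7-fold lower number (0.44 log units; beyond the scatter)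

All three compounds carry a five-membered aromatic ring on this aromatic carbon, so the compounds shown leave open how a saturated amine such as morpholine would fare there in the adenosine receptor A1 assay.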